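Swapping a branched acid chain for a straight one

This account rests on a few compounds, and the source may have more. Where it says the series, first, only, none or still open, it means among the compounds named here.

Measured so far:
compound 1 `CC(C)(Oc1ccc([C@H]2CC[C@]3(CC2)OOC2(O3)C3CC4CC(C3)CC2C4)cc1)C(=O)O`: 7 mL.min-1.g-1
compound 2 `O=C(O)COc1ccc([C@H]2CC[C@]3(CC2)OOC2(O3)C3CC4CC(C3)CC2C4)cc1C(=O)O`: 8 mL.min-1.g-1
compound 3 `O=C(O)COc1ccc([C@H]2CC[C@]3(CC2)OOC2(O3)C3CC4CC2CC(C3)C4O)cc1`: a limit, < 7 mL.min-1.g-1

In an ADME assay on microsomes from liver (Mus musculus) for metabolic stability, using NADPH, with a stated time of 60 min, in the presence of a further agent that is not named here (on this read-out lower numbers stand for slow clearance and higher numbers for fast clearance), compound 1 gives 7 mL.min-1.g-1, the lowest of the two numbers reported. Compound 2 gives 8 mL.min-1.g-1, which lies within the scatter of the value for compound 1, so the two cannot be told apart. For compound 3 only the limit of < 7 mL.min-1.g-1 in this assay, at which 1 of the 3 values shown sits, is reported, and this is a limit of the assay rather than a number.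

Compound 4 `O=C(O)CCCCOc1ccc([C@H]2CC[C@]3(CC2)OOC2(O3)C3CC4CC(C3)CC2C4)cc1` has not yet been measured. It differs from compound 1 in one place: 4-carboxybutyl in place of 1-carboxy-1-methylethyl on an oxygen on an aromatic ring. Within the data shown here, no measured step covers such a change. Compound 4 is expected to clear somewhat faster than compound 1, with an estimated step of a 2.0-fold higher number from compound 1 to compound 4 (0.30 log units; within the scatter), which may reach beyond the scatter. In this assay compound 4 is estimated at 14 mL.min-1.g-1, within a range from 7 mL.min-1.g-1 to 30 mL.min-1.g-1.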

Compound 4, intrinsic clearance in microsomes: 13 mL.min-1.g-1
Compound 4: the middle estimate sits 1.1-fold (0.03 log units) above what was measured; measured number inside the range.
By their numbers in this assay, from the lowest: compounds 1, 2 and 4 (each within the scatter of the next).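

Among these compounds, this is the first one-place step at this position, so the earlier compounds could not show what it shows. In this assay, putting 4-carboxybutyl in place of 1-carboxy-1-methylethyl on the oxygen gives a 1.9-fold higher number from compound 1 to compound 4 (0.27 log units; within the scatter), so the two compounds cannot be told apart and clearance does not clearly respond to this swap. Nothing measured here bears on why the step has this size. Still open, going by these compounds, is whether a longer chain would also stay within the scatter of compound 1. Also open, on these data alone, is how an amine in place of the carboxylic acid would behave.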